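A few compounds are considered here, and "the series" means these few. Any claim that something is new, unique, unknown or untested is made for them only; others in the source may bear on it.

In a functional assay on MKN-45 cells (Homo sapiens) for inhibition, read by MTT assay, with a stated time of 72 h (on this read-out lower numbers stand for stronger inhibition and higher numbers for weaker inhibition), compound 2 `COc1cc2c(Oc3ccc(NC(=O)c4nn(-c5ccccc5OC(F)(F)F)c(=O)cc4C)cc3F)ccnc2cc1OCCCN1CCCCC1` gives 40 nM. Its only companion among the measured compounds is compound 1 `COc1cc2c(Oc3ccc(NC(=O)c4nn(-c5ccccc5OC(F)(F)F)c(=O)cc4C)cc3F)ccnc2cc1OCCCN1CCCC1`, which in this assay gives 60 nM; the two numbers sit within the scatter of each other, and the step of a 1.5-fold lower number from compound 1 to compound 2 (0.18 log units; within the scatter) is the whole of what is known about changing the amine at the end of the chain. Compound 3 `COc1cc2c(Oc3ccc(NC(=O)c4nn(-c5ccccc5OC(F)(F)F)c(=O)cc4C)cc3F)ccnc2cc1OCCCN1CCC(C)CC1` is next. It differs from compound 2 by methyl in place of hydrogen on a saturated ring carbon. Within the data shown here, no measured pair shows a methyl added to a saturated ring carbon of this amine; the one step that touches the same region, from compound 1 to compound 2, concerned the size of the ring rather than a substituent on it and was within the scatter. With nothing in hand pointing in either direction, he expects no shift beyond the scatter for compound 3, which means an estimated step of a 1.1-fold higher number from compound 2 to compound 3 (0.05 log units; within the scatter). His estimate for compound 3 in this assay is therefore 45 nM, with a range from 20 nM to 110 nM.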

Compound 3, half-maximal inhibitory concentration: 70 nM
Compound 3: the middle estimate sits 1.6-fold (0.19 log units) below what was measured; the range from low to high includes it.
By their numbers in this assay, from the lowest: compounds 2, 1 and 3 (each within the scatter of the next).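

In this assay, among these compounds, the methyl on the saturated ring carbon, three ring bonds from the ring nitrogen, is the first substituent seen on this amine ring, and it gives a 1.8-fold higher number from compound 2 to compound 3 (0.24 log units; within the scatter) as its step, so at this position the added methyl produces no shift that can be told from the scatter. The wider change from pyrrolidin-1-yl to 4-methylpiperidin-1-yl gives a 1.2-fold higher number from compound 1 to compound 3 (0.07 log units; within the scatter) and likewise stays inside the scatter, so the amines at the end of the chain in compounds 1, 2 and 3 cannot be separated on these numbers. Nothing measured here offers an explanation for why these amines behave alike.

As far as these compounds go, whether a different kind of amine at the end of the chain, such as morpholin-4-yl or 4-methylpiperazin-1-yl, would move the number beyond the scatter remains open, as does the effect of a hydroxyl or a larger alkyl group in place of the methyl on this ring carbon. The compounds shown also all carry the same three-carbon propyl link to the amine, so a shorter or longer chain remains an open question.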